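Replacing the Fluorophenyl Group: A Step Into the Unknown

The compounds below may be only part of what the source reports. "The series", "measured", "known", "first", "only" and "open" are said of these compounds alone.

In a toxicity assay on HepG2 2.2.15 cells (Homo sapiens) for cytotoxicity, read by CellTiter-Glo (a higher number here means that more compound is tolerated, a lower number that less compound is tolerated), compound 1 `O=C(Nc1cc(F)c(F)c(F)c1)N1Cc2c(-c3ccc(F)cc3F)cnn2CC1C1CC1` gives 32100 nM and compound 2 `O=C(Nc1cc(F)c(F)c(F)c1)N1Cc2c(-c3ccc(F)cc3)cnn2CC1C1CC1` gives 38500 nM. For the measured compounds named here, the only measured step is a 1.2-fold higher number from compound 1 to compound 2 (0.08 log units; within the scatter), so compound 2 cannot be told apart from compound 1. Compound 3 `Cc1nc(C2CC(=O)N(c3cnn4c3CN(C(=O)Nc3cc(F)c(F)c(F)c3)C(C3CC3)C4)C2)no1` keeps the shared core but carries a much larger change: 4-(5-methyl-1,2,4-oxadiazol-3-yl)-2-oxopyrrolidin-1-yl in place of 4-fluorophenyl on an aromatic carbon. In short, 4-(5-methyl-1,2,4-oxadiazol-3-yl)-2-oxopyrrolidin-1-yl takes the place of 4-fluorophenyl on an aromatic carbon. The measured step, hydrogen in place of fluoro, offers only a weak guide, since it leaves the aromatic ring in place. Going by the values given here, no measured pair shows a swap of this whole group, so the direction remains uncertain. Only a small upward shift is expected, with nothing firmly beyond the scatter. The expected change is a 1.3-fold higher number from compound 2 to compound 3 (0.11 log units; within the scatter). For compound 3 the estimate is 50000 nM, with an expected range from 15000 nM to 100000 nM.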

Compound 3, half-maximal cytotoxic concentration: > 200000 nM
Compound 3: no number, only a limit; the forecaster's own chance of this, stated with the estimate: 35%; at least 4.0-fold (0.60 log units) between middle value and limit.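

In this assay, exchanging the whole 4-fluorophenyl group for 4-(5-methyl-1,2,4-oxadiazol-3-yl)-2-oxopyrrolidin-1-yl on this aromatic carbon gives a shift that can be told apart from the scatter, with an at least 5.1-fold higher number from compound 2 to compound 3 (0.71 log units; beyond the scatter). The comparison with the 2,4-difluorophenyl group points the same way, with an at least 6.2-fold higher number from compound 1 to compound 3 (0.79 log units; beyond the scatter), whereas the earlier hydrogen-for-fluoro step stayed within the scatter. Compound 3 stands at a limit of the assay rather than at a number, so both steps give only a minimum size: the limit of > 200000 nM in this assay, at which 1 of the 3 values shown sits.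

The compounds shown leave open whether the shift belongs to the 2-oxopyrrolidin-1-yl ring, to the 5-methyl-1,2,4-oxadiazol-3-yl ring, or to the loss of the phenyl ring itself. They also leave open how a smaller group, such as a simple amine or a carboxylic acid, would read at this position.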